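Replacing 2-Chlorophenyl with 3-Bromophenyl on the Amine Nitrogen

The compounds below may be only part of what the source reports. "The series", "measured", "known", "first", "only" and "open" are said of these compounds alone.

Compound 1 `CCCCCCNc1nc(SCc2ccc(C(F)(F)F)cc2)nc2ccccc12` gives 24300 nM in a functional assay on MCF7 cells (Homo sapiens) for cytotoxicity, read by MTT assay, with a stated time of 72 h; a higher number here means a weaker inhibitor, a lower number a stronger inhibitor. Compound 2 `CCCCCCCCNc1nc(SCc2ccc(C(F)(F)F)cc2)nc2ccccc12` gives 26100 nM in this assay, and the step of a 1.1-fold higher number from compound 1 to compound 2 (0.03 log units; within the scatter) lies within the scatter. Compound 3 `FC(F)(F)c1ccc(CSc2nc(Nc3ccccc3Cl)c3ccccc3n2)cc1` reaches only a limit in this assay, reported as > 50000 nM. This is the limit at which one of the three values sits (the limit of > 50000 nM in this assay, at which 1 of the 3 values shown sits). The aryl amine of compound 3 thus stands at the weak end: the step of an at least 2.0-fold higher number from compound 1 to compound 3 (0.31 log units; beyond the scatter) is at least modest, while the step of an at least 1.9-fold higher number from compound 2 to compound 3 (0.28 log units; that floor lies within the scatter) has a floor that lies within the scatter.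

Compound 4 `FC(F)(F)c1ccc(CSc2nc(Nc3cccc(Br)c3)c3ccccc3n2)cc1` differs from compound 3 by 3-bromophenyl in place of 2-chlorophenyl on a nitrogen on an aromatic ring. For the measured compounds named here, no measured step moves a halogen from one position of the aryl ring to another, so only the two steps into compound 3 bear on compound 4, and both end at the limit. Compound 4 is therefore expected to remain at or near that limit, with a step that the limit leaves unreadable from compound 3 to compound 4 estimated as none beyond the scatter. Compound 4 is expected to give about 60000 nM, in the range 25000 nM to 150000 nM.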

Compound 4, half-maximal inhibitory concentration: 25600 nM
Estimate against measurement, compound 4: 2.3-fold (0.37 log units) above, within the range that was stated.
By their numbers in this assay, from the lowest: compounds 1, 4 and 2 (each within the scatter of the next). At a limit, above all of these: compound 3.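

With 3-bromophenyl on the nitrogen, an aryl group does not by itself bring a compound to the limit in this assay: replacing hexyl gives a 1.1-fold higher number from compound 1 to compound 4 (0.02 log units; within the scatter), and replacing octyl gives a 1.0-fold lower number from compound 2 to compound 4 (0.01 log units; within the scatter). Compound 3 stands at a limit of this assay, which is no measured number: the limit of > 50000 nM in this assay, at which 1 of the 4 values shown sits. Against that limit, the change of aryl group reads as an at least 1.9-fold lower number from compound 3 to compound 4 (0.29 log units; that floor lies within the scatter), so the true gap between 2-chlorophenyl and 3-bromophenyl remains undefined.

These two aryl groups differ in both the halogen and its place on the ring, and a 3-chlorophenyl group on the same nitrogen would separate those two changes. From the compounds shown here alone, it also remains open whether another group on this nitrogen, such as benzyl or cyclohexyl, would move the value beyond the scatter of compounds 1, 2 and 4.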